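This account rests on a few compounds, and the source may have more. Where it says the series, first, only, none or still open, it means among the compounds named here.

Working notes on the cytotoxicity series

Compound 1 `Cc1ncnc2c1c(-c1cc3ccccc3o1)cn2[C@@H]1O[C@H](CO)[C@@H](O)[C@H]1O` and compound 2 `Cc1nc(N)c2c(-c3cc4ccccc4o3)cn([C@@H]3O[C@H](CO)[C@@H](O)[C@H]3O)c2n1` share the same nucleoside scaffold with a 1-benzofuran-2-yl group; the difference between the two cores is not broken down here. In an ADME assay on MRC5 cells (Homo sapiens), read by MTT assay, with a stated time of 72 h (a higher number here means a weaker inhibitor, a lower number a stronger inhibitor), compound 1 gives 84400 nM. In this assay compound 2 gives 91800 nM, which lies within the scatter of compound 1, so no order is drawn between them.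

Compound 3 `Cc1ncnc2c1c(-c1ccsc1)cn2[C@@H]1O[C@H](CO)[C@@H](O)[C@H]1O` carries the change (thiophen-3-yl in place of 1-benzofuran-2-yl on an aromatic carbon). Compound 3 returns only a limit in this assay, > 100000 nM. The step of an at least 1.1-fold higher number from compound 1 to compound 3 (0.07 log units; that floor lies within the scatter) therefore rests on (the limit of > 100000 nM in this assay, at which 1 of the 3 values shown sits), and its floor lies within the scatter.

Compound 4 `Cc1nc(N)c2c(-c3ccsc3)cn([C@@H]3O[C@H](CO)[C@@H](O)[C@H]3O)c2n1` is the same kind of change applied to compound 2, namely (thiophen-3-yl in place of 1-benzofuran-2-yl on an aromatic carbon); the place lines of the two changes read the same word for word. Compound 2 already sits at a high number with 91800 nM, and the step of an at least 1.1-fold higher number from compound 1 to compound 3 (0.07 log units; that floor lies within the scatter) ran toward a weaker number, so the expected step of a 1.2-fold higher number from compound 2 to compound 4 (0.08 log units; within the scatter) is small. The expected value for compound 4 is 110000 nM, with a range from 70000 nM to 200000 nM.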

Compound 4, half-maximal inhibitory concentration: > 100000 nM
Compound 4 was reported as a limit; the forecaster's own chance of this, stated with the estimate: 60%; the middle value is on the limit's open side.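

In this assay compound 4 is reported only as a limit (> 100000 nM). Thiophen-3-yl in place of 1-benzofuran-2-yl on the core of compound 2 gives an at least 1.0-fold higher number from compound 2 to compound 4 (0.03 log units; that floor lies within the scatter), so the floor of this step shows no difference beyond the scatter, and the true size of the step remains unknown. The two cores therefore give no evidence that the change carries over either alike or differently, since neither step has a measured end point and the comparison stays unresolved: (the same change on two cores in this assay, an at least 1.1-fold higher number (0.07 log units; that floor lies within the scatter) from compound 1 to compound 3 and an at least 1.0-fold higher number (0.03 log units; that floor lies within the scatter) from compound 2 to compound 4; the limit leaves it open whether they differ).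

Neither thiophen-3-yl compound offers a number for a closer comparison, and the series reaches the ceiling of the assay at these compounds: (the limit of > 100000 nM in this assay, at which 2 of the 4 values shown sit). Still open, from the compounds shown here alone, is whether an amine or a carboxylic acid on that aromatic carbon, two ring bonds from the ring nitrogen, would give a measurable value in this assay on either core.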